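The source may report more compounds than this note shows. Statements on the series, on what has been measured and on what is new or still open speak of the compounds shown alone.

Three compounds share one core and differ only in the group on an amine nitrogen in a ring. Compound 1 `Nc1nc(N)c2cc(CSC(=S)N3CCN(c4ccc(O)cc4)CC3)ccc2n1` gives 4210 nM in a functional assay on A549 cells (Homo sapiens) for antiproliferative activity, read by MTT assay, with a stated time of 72 h; a lower number here means a stronger inhibitor, a higher number a weaker inhibitor; compound 2 `Cc1ccc(N2CCN(C(=S)SCc3ccc4nc(N)nc(N)c4c3)CC2)c(C)c1` gives 3000 nM; compound 3 `Nc1nc(N)c2cc(CSC(=S)N3CCN(c4ccc(Cl)cc4)CC3)ccc2n1` gives 5210 nM. Compound 2 has the lowest of these three numbers, but both neighbours sit within the scatter: a 1.4-fold lower number from compound 1 to compound 2 (0.15 log units; within the scatter) and a 1.7-fold higher number from compound 2 to compound 3 (0.24 log units; within the scatter). As far as these compounds go, compound 4 `Nc1nc(N)c2cc(CSC(=S)N3CCN(c4ccccc4[N+](=O)[O-])CC3)ccc2n1` is untested and alters the same position again: 2-nitrophenyl in place of 2,4-dimethylphenyl on an amine nitrogen in a ring. Both earlier swaps at that position, and also a 1.2-fold higher number from compound 1 to compound 3 (0.09 log units; within the scatter), stayed within the scatter, so in this assay no step beyond the scatter is expected. Compound 4 is therefore estimated at 3600 nM, within 1500 nM to 8500 nM. For compound 4 the expected step is a 1.2-fold higher number from compound 2 to compound 4 (0.08 log units; within the scatter).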

Compound 4, half-maximal inhibitory concentration: 4360 nM
Estimate against measurement, compound 4: 1.2-fold (0.08 log units) below; measured number inside the range.
By their numbers in this assay, from the lowest: compounds 2, 1, 4 and 3 (each within the scatter of the next).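

In this assay, 2-nitrophenyl puts hydrogen-bond acceptors at this position, which 2,4-dimethylphenyl lacks, yet the number barely moves (a 1.5-fold higher number from compound 2 to compound 4 (0.16 log units; within the scatter)). The other two steps also stay within the scatter (a 1.2-fold lower number from compound 3 to compound 4 (0.08 log units; within the scatter)) and (a 1.0-fold higher number from compound 1 to compound 4 (0.02 log units; within the scatter)), so all four groups on this ring nitrogen are indistinguishable in this test. No measured evidence here offers an explanation for that. Still open, as far as these compounds go, is whether an amine or a carboxylic acid on the phenyl ring, or a longer chain replacing that ring, would give a step beyond the scatter.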